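Swapping the Oxazolidinone Arm: Expected Cytotoxicity of Compound 3

The source may hold more compounds than are shown below. What is called first, only, known or untested is meant among the compounds shown, and "the series" means these compounds.

Compound 1, `O=C1OC(c2ccccc2)CN1c1cnn2c1CN(C(=O)Nc1cc(F)c(F)c(F)c1)C(C1CC1)C2`: 7410 nM
Compound 2, `CC1CN(C(=O)Nc2cc(F)c(F)c(F)c2)Cc2c(N3CC(C#N)CC3=O)cnn21`: 115000 nM

Of the compounds shown here, two sharing the same core have been measured in a toxicity assay on HepG2 2.2.15 cells (Homo sapiens) for cytotoxicity, read by CellTiter-Glo; a lower number here means that less compound is tolerated, a higher number that more compound is tolerated. Compound 1 gives 7410 nM in this assay, the lowest of the two numbers, so it is the less tolerated of the pair. Compound 2 gives 115000 nM, a clearly higher number that sits well beyond the scatter of the measurement. The two compounds differ in more than one place, so no single structural change can be tied to that gap.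

Compound 3, `O=C1CC(c2ncco2)CN1c1cnn2c1CN(C(=O)Nc1cc(F)c(F)c(F)c1)C(C1CC1)C2`, has not yet been measured. It is reached from compound 1 by one change: 4-(1,3-oxazol-2-yl)-2-oxopyrrolidin-1-yl in place of 2-oxo-5-phenyl-1,3-oxazolidin-3-yl on an aromatic carbon. Among the compounds with values here, no measured pair shows exactly this kind of exchange, so there is no directly comparable step to lean on. Compound 2, which also carries a 2-oxopyrrolidin-1-yl group, gives the higher number, and on that basis an upward step of moderate size, toward better tolerance, is expected, though it could well fall within the scatter. The step from compound 1 to compound 3 is estimated as a 2.7-fold higher number from compound 1 to compound 3 (0.43 log units; beyond the scatter). Compound 3 is therefore expected to give about 20000 nM in this assay, with a likely range from 6000 nM to 80000 nM.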

Compound 3, half-maximal cytotoxic concentration: > 200000 nM
Compound 3: no number, only a limit; the forecaster's own chance of this, stated with the estimate: 20%; middle value at least 10-fold (1.00 log units) away from the limit.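

In this assay compound 3 gives > 200000 nM as a limit of the assay and not as a number. Within the data shown here, compounds 1 and 3 are the first pair here that differ in one place only, so this is the first time a shift in this read-out can be tied to a single group: putting 4-(1,3-oxazol-2-yl)-2-oxopyrrolidin-1-yl in place of 2-oxo-5-phenyl-1,3-oxazolidin-3-yl gives an at least 26-fold higher number from compound 1 to compound 3 (1.43 log units; beyond the scatter) on the same core. The group on this aromatic carbon alone, with the rest of compound 1 unchanged, is therefore enough to move the result from a measured value to the limit of the assay: the limit of > 200000 nM in this assay, at which 1 of the 3 values shown sits.

Both rings of the group change at once in this exchange, so the compounds shown do not separate the effect of losing the phenyl ring from that of swapping the ring that carries the carbonyl. From the compounds shown here alone, whether a methyl group or a primary amine in place of the oxazole on the 2-oxopyrrolidin-1-yl ring would also reach this limit remains open.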